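The source may report more compounds than this note shows. Statements on the series, on what has been measured and on what is new or still open speak of the compounds shown alone.

Compound 1 `O=c1c([C@@H]2C[C@H](c3ccccc3)ON2c2ccccc2)coc2ccc(F)cc12` gives 54700 nM in a functional assay on THP-1 cells (Homo sapiens) for inhibition, read by sulforhodamine B assay, with a stated time of 48 h (on this read-out lower numbers stand for stronger inhibition and higher numbers for weaker inhibition), and compound 3 `N#C[C@H]1C[C@@H](c2coc3ccc(Cl)cc3c2=O)N(c2ccccc2)O1` gives 35000 nM. Compound 2 `O=c1c([C@@H]2C[C@H](c3ccccc3)ON2c2ccccc2)coc2ccccc12` is recorded only as a limit of this assay, > 60000 nM. For the measured compounds named here, the one measured step, an at least 1.0-fold higher number from compound 1 to compound 2 (0.04 log units; that floor lies within the scatter), rests on that limit of > 60000 nM in this assay, at which 1 of the 3 values shown sits, and so sets only a floor. Compound 4 `O=c1c([C@@H]2C[C@H](c3ccncc3)ON2c2ccccc2)coc2ccccc12` differs from compound 2 by pyridin-4-yl in place of phenyl on a saturated ring carbon. Going by the values given here, no measured pair exchanges phenyl for pyridin-4-yl on that saturated ring carbon, so no measured step bears directly on this change; the three values shown all sit near the weak end of this assay. The step from compound 2 to compound 4 is therefore expected to be a number no higher from compound 2 to compound 4 (the limit leaves the size open), none beyond the scatter. Compound 4 is estimated at 60000 nM, within 20000 nM to 150000 nM.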

Compound 4, half-maximal inhibitory concentration: 16400 nM
The estimate for compound 4 lay 3.7-fold (0.56 log units) above the measured number; the whole stated range lies above it.
By their numbers in this assay, from the lowest: compound 4; then compounds 3 and 1 (each within the scatter of the next). At a limit, above all of these: compound 2.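

In this assay, exchanging phenyl for pyridin-4-yl on the saturated ring carbon next to the ring oxygen gives an at least 3.6-fold lower number from compound 2 to compound 4 (0.56 log units; beyond the scatter), the only step shown that lies beyond the scatter. For the compounds shown here, no earlier step touched this position, so this is the first sign that the number responds to a change there. Compound 2 is recorded only as a limit, so the step sets a floor and not an exact size: the limit of > 60000 nM in this assay, at which 1 of the 4 values shown sits.

The compounds shown leave open how an amine or a carboxylic acid on this carbon would read. They also leave open whether pyridin-4-yl would lower the number on a core that carries fluoro.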